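Arylpiperazine indole amides: antagonist binding notes

The source may report more compounds than this note shows. Statements on the series, on what has been measured and on what is new or still open speak of the compounds shown alone.

Measured so far:
compound 1 `COc1ccccc1N1CCN(CCCNC(=O)CCc2c[nH]c3ccccc23)CC1`: 195 nM
compound 2 `COc1ccccc1N1CCN(CCCNC(=O)c2cc3cc(O)ccc3[nH]2)CC1`: 55 nM

In an assay on isolated protein (Vas deferens, strain Sprague-Dawley) for antagonist activity at Alpha-1A adrenergic receptor (Rattus norvegicus), with a stated time of 20 min (a higher number here means weaker binding, a lower number tighter binding), compound 2 gives 55 nM, the lower of the two numbers; compound 1 gives 195 nM, a gap beyond the scatter. Compound 3 `COc1ccccc1N1CCN(CCCNC(=O)c2cn(C)c3ccccc23)CC1` is not yet measured. It differs from compound 2 by 1-methyl-1H-indol-3-yl in place of 5-hydroxy-1H-indol-2-yl on a carbonyl carbon. Both hydrogen-bond donors of the departing group are lost and the methylated ring is attached through a different ring carbon, so the step from compound 2 is expected to go toward weaker binding by a 2.9-fold higher number from compound 2 to compound 3 (0.46 log units; beyond the scatter), beyond the scatter. Compound 3 is estimated at 160 nM, with a range from 50 nM to 500 nM.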

Compound 3, dissociation constant: 52.5 nM
Beside the measured number, compound 3's estimate is 3.0-fold (0.48 log units) above it, within the range that was stated.
By their numbers in this assay, from the lowest: compounds 3 and 2 (each within the scatter of the next); then compound 1.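

On a carbonyl carbon whose other neighbour is the amide-type nitrogen, 1-methyl-1H-indol-3-yl in place of 5-hydroxy-1H-indol-2-yl gives a 1.0-fold lower number from compound 2 to compound 3 (0.02 log units; within the scatter) in this assay. The entering group carries no hydrogen-bond donors, so donors on this group are not required for binding at this level in this pair. No available evidence explains why the two groups read alike.

The separate contributions of the hydroxy group, the methyl group and the point of attachment remain unresolved within this single step. Also open, on these data alone, is how a methoxy group or a carboxylic acid on the indole ring would read.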